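The compounds below may be only part of what the source reports. "The series", "measured", "known", "first", "only" and "open" are said of these compounds alone.

In a functional assay on the whole organism (Ehrlich cells, Mus musculus) for antiproliferative activity, with a stated time of 24 h, at a dose of 0.2 mmol/kg by the intraperitoneal route (a higher number here means more inhibition at the dose given (going by the name of the read-out), a lower number less inhibition), compound 2 `Nc1ccccc1NC(=O)CCCNCC(=O)Nc1ccc(Br)cc1` gives 68.7%, the second highest of three numbers. Compound 1 `Nc1ccccc1NC(=O)CCCNCC(=O)Nc1ccc(Cl)cc1` gives 75%, within the scatter of compound 2, while compound 3 `Nc1ccccc1NC(=O)c1ccc(NCC(=O)Nc2cccc([N+](=O)[O-])c2)cc1` gives 40.4%, a gap beyond the scatter. Compound 4 `Nc1ccccc1NC(=O)CCCNCC(=O)Nc1cc(Cl)ccc1Cl` has not yet been measured; it differs from compound 2 by 2,5-dichlorophenyl in place of 4-bromophenyl on an amide-type nitrogen. Among the compounds with values here, only one measured step bears on this change: a number 6.3 percentage points lower from compound 1 to compound 2 (within the scatter), an exchange of one halogen for another on the aryl amide that stayed within the scatter. Within the data shown here, no measured step covers two chlorines in place of one bromine, so one expects in this assay a small step, possibly downward, not clearly beyond the scatter. Compound 4 is therefore estimated at 63%, with a range from 45% to 80%. The expected step is a number 5.7 percentage points lower from compound 2 to compound 4 (within the scatter).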

Compound 4, a percentage reported as inhibition, in the whole organism at one dose (the size of the read-out at that dose, not a potency): 50.9%
Compound 4: middle estimate off by 12.1 percentage points, on the high side; the range from low to high includes it.
By their numbers in this assay, from the lowest: compound 3; then compound 4; then compounds 2 and 1 (each within the scatter of the next).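

In this assay the group on the amide-type nitrogen turns out to matter: 2,5-dichlorophenyl in place of 4-bromophenyl gives a number 17.8 percentage points lower from compound 2 to compound 4 (beyond the scatter) and in place of 4-chlorophenyl gives a number 24.1 percentage points lower from compound 1 to compound 4 (beyond the scatter) in the same series. The earlier exchange of one halogen for another had not shown a step of this kind at this place. Nothing measured here gives a reason for these steps. The compounds shown leave open how an unsubstituted phenyl or a methoxyphenyl group would fare on this nitrogen.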